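The compounds below may be only part of what the source reports. "The series", "measured", "known", "first", "only" and "open" are said of these compounds alone.

Measured so far in a functional assay on MV4-11 cells (Homo sapiens) for inhibition, read by resazurin assay, with a stated time of 72 h; on this read-out lower numbers stand for stronger inhibition of growth and higher numbers for weaker inhibition of growth:
compound 1 `CNc1nc(C)c(-c2ccnc(Nc3ccc(OC)cc3OC)n2)s1`: 300 nM
compound 2 `COc1ccc(Nc2nccc(-c3c[nH]c4ccccc34)n2)c(OC)c1`: 600 nM

Compound 1 at 300 nM and compound 2 at 600 nM lie within the scatter of each other, so the two numbers do not separate them. Compound 3 `COc1ccc(Nc2nccc(-c3sc(OC(C)C)nc3C)n2)c(OC)c1` keeps the core of compound 1 and carries isopropoxy in place of methylamino on an aromatic carbon. This carbon stands next to the ring nitrogen and next to the ring sulfur of the five-membered aromatic ring. Within the data shown here, no measured pair covers this change, so the expectation is tentative. A modest step in this assay is expected, towards a higher number and so weaker inhibition of growth, though a result within the scatter would not surprise. The estimated change is a 3.0-fold higher number from compound 1 to compound 3 (0.48 log units; beyond the scatter). The expected value for compound 3 is 900 nM, with an estimated range of 300 nM to 3000 nM.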

Compound 3, concentration for 50% growth inhibition: 8690 nM
Estimate against measurement, compound 3: 9.7-fold (0.98 log units) below; the whole stated range lies below it.
By their numbers in this assay, from the lowest: compounds 1 and 2 (each within the scatter of the next); then compound 3.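

In this assay the aromatic carbon next to the ring nitrogen and next to the ring sulfur proves sensitive to its substituent: isopropoxy in place of methylamino gives a 29-fold higher number from compound 1 to compound 3 (1.46 log units; beyond the scatter) and so a large step beyond the scatter. This one change exchanges methylamino, with 2 heavy atoms and 1 hydrogen-bond donor, for isopropoxy, with 4 heavy atoms and 0 hydrogen-bond donors, so the compounds cannot assign the step to any one of these differences. No supporting measurement bears on the origin of this step.

The compounds shown leave open whether the amino hydrogen, the oxygen link or the size of the group governs the result at this carbon. Methoxy, ethylamino and dimethylamino there would help to separate these differences.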